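Phenyl in place of allyl on an aromatic nitrogen

The compounds below may be only part of what the source reports. "The series", "measured", "known", "first", "only" and "open" are said of these compounds alone.

Two compounds of the series carry numbers in a functional assay on the whole organism (strain albino) for inhibition, with Rattus norvegicus as the target, read by paw edema, with stated times of 30 min and 1 h, at a dose of 0.28 mmol/kg by the oral route; on this read-out higher numbers stand for more inhibition at the one dose given (going by the name of the read-out) and lower numbers for less inhibition. Compound 1 `COc1ccc(-c2nnc(SCC(=O)Nc3ccc(/C(C)=N/O)cc3)n2-c2ccccc2)cc1` gives 45%. Compound 2 `C=CCn1c(SCC(=O)Nc2ccc(C(C)=O)cc2)nnc1-c1ccc(OC)cc1` gives 50%. Compound 2 has the larger of the two numbers, yet its gap to compound 1 lies within the usual scatter, so no ranking follows from it.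

Compound 3 `COc1ccc(-c2nnc(SCC(=O)Nc3ccc(C(C)=O)cc3)n2-c2ccccc2)cc1` has not yet been measured in this assay. It differs from compound 2 in one place: phenyl in place of allyl on an aromatic nitrogen. Among the measured compounds shown here, no step between measured compounds isolates this change. Compound 1 carries the same phenyl on the same aromatic nitrogen but differs from compound 2 elsewhere as well, so its value is only a loose guide.

Because compound 1 gives 45% and compound 2 gives 50%, the expected step from compound 2 to compound 3 is a number 3 percentage points lower from compound 2 to compound 3 (within the scatter), nothing beyond the scatter. Compound 3 is estimated at 47%, with a range from 35% to 59%.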

Compound 3, a percentage reported as inhibition, in the whole organism at one dose (the size of the read-out at that dose, not a potency): 29%
For compound 3 the middle estimate is 18 percentage points above the measured one; the measured number lies below the stated range.
By their numbers in this assay, from the lowest: compound 3; then compounds 1 and 2 (each within the scatter of the next).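

In this assay, among the compounds shown here, the aromatic nitrogen is sensitive to the change of group: phenyl in place of allyl gives a number 21 percentage points lower from compound 2 to compound 3 (beyond the scatter), the first reading of this change in isolation. The group on the aromatic carbon also counts when phenyl stays in place: the group of 3 heavy atoms in place of the group of 4 heavy atoms gives a number 16 percentage points lower from compound 1 to compound 3 (beyond the scatter), so the value for phenyl on this nitrogen depends on what the aromatic carbon carries. No measurement at hand accounts for either step.

On these data alone, whether allyl in place of phenyl has the same effect alongside the group of 4 heavy atoms stays open. So does the standing of benzyl or a propyl chain on the aromatic nitrogen relative to allyl and phenyl.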